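A Chloro-to-Bromo Swap on an Aromatic Carbon

A few compounds are considered here, and "the series" means these few. Any claim that something is new, unique, unknown or untested is made for them only; others in the source may bear on it.

compound 1: `CC1(C)S[C@@H]2/C(=C\C(=O)c3ccc4ccccc4c3)C(=O)N2[C@H]1C(=O)OC(c1ccccc1)c1ccccc1` — 36500 nM
compound 2: `CC1(C)S[C@@H]2/C(=C\C(=O)c3ccc(Cl)cc3)C(=O)N2[C@H]1C(=O)OC(c1ccccc1)c1ccccc1` — 48600 nM

In a functional assay on A-375 cells (Homo sapiens) for cytotoxicity, read by MTT assay, with a stated time of 48 h (a higher number here means a weaker inhibitor, a lower number a stronger inhibitor), compound 1 gives 36500 nM. In the same assay compound 2 gives 48600 nM. For the measured compounds named here, the only measured step, a 1.3-fold higher number from compound 1 to compound 2 (0.12 log units; within the scatter), exchanges one ring system for another on the carbonyl carbon and stays within the scatter. Compound 2 therefore holds the highest of the two numbers, but its gap to compound 1 is within the scatter, so no order can be read from these two.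

Compound 3 `CC1(C)S[C@@H]2/C(=C\C(=O)c3ccc(Br)cc3)C(=O)N2[C@H]1C(=O)OC(c1ccccc1)c1ccccc1` differs from compound 2 by bromo in place of chloro on an aromatic carbon. Going by the values given here, no measured step touches this halogen position, and the one step that exists, a 1.3-fold higher number from compound 1 to compound 2 (0.12 log units; within the scatter), was within the scatter. In this assay compound 3 is therefore expected near compound 2, with a step of a 1.1-fold lower number from compound 2 to compound 3 (0.03 log units; within the scatter) and no change beyond the scatter. The estimate for compound 3 in this assay is 45000 nM, with a range from 20000 nM to 100000 nM.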

Compound 3, half-maximal inhibitory concentration: 29700 nM
The estimate for compound 3 lay 1.5-fold (0.18 log units) above the measured number; the range from low to high includes it.
By their numbers in this assay, from the lowest: compounds 3, 1 and 2 (each within the scatter of the next).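

In this assay, the halogen position gets its first reading: bromo in place of chloro on an aromatic carbon, para to a large group, gives a 1.6-fold lower number from compound 2 to compound 3 (0.21 log units; within the scatter) and so leaves the number unmoved beyond the scatter. The exchange of naphthalen-2-yl for 4-bromophenyl on the carbonyl carbon gives a 1.2-fold lower number from compound 1 to compound 3 (0.09 log units; within the scatter) and also stays inside that scatter. All three groups carried on the carbonyl carbon therefore sit within the scatter of one another, and no order among them can be read. No supporting measurement is available to explain this flat picture. The compounds shown leave open whether an amine, a carboxylic acid or a methoxy group at this place would shift the number beyond the scatter. They also leave open whether a change elsewhere on the shared core would do so.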